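The source may hold more compounds than are shown below. What is called first, only, known or untested is meant among the compounds shown, and "the series" means these compounds.

Working notes on a series of agonists at a functional assay on CHO cells for agonist activity at Melanocyte-stimulating hormone receptor (Homo sapiens), read by a luciferase reporter, with a stated time of 4 h; a higher number here means that more compound is needed for the effect, a lower number that less compound is needed. Compound 1 `CC(C)N(C(=O)CN1C=CN(c2ccccc2)C(=O)C(Cc2n[nH]c3ccccc23)C1=O)c1ccc(OC(F)(F)F)cc1` gives 22.4 nM in this assay. Compound 2 `COc1ccc(N(C(=O)CN2C=CN(c3ccccc3)C(=O)[C@H](Cc3n[nH]c4ccccc34)C2=O)C(C)C)cc1` gives 15.9 nM, which sits within the scatter of compound 1, so no order between the two is claimed. Compound 3 `COc1ccc(N(C(=O)CN2C=CN(Cc3cccs3)C(=O)C(Cc3n[nH]c4ccccc34)(OC)C2=O)C(C)C)cc1` gives 1170 nM, a gap from compound 2 that lies beyond the scatter; compound 3 differs in several places at once, so no single cause is drawn. Compound 4 `CC(C)N(C(=O)CN1C=CN(c2ccccc2)C(=O)[C@H](Cc2n[nH]c3ccccc23)C1=O)c1ccccc1` has not yet been measured. Its difference from compound 2 is hydrogen in place of methoxy on an aromatic carbon. Compound 1 carries a trifluoromethoxy group where compound 2 carries methoxy, and the two values are within the scatter, so the step from compound 2 to compound 4 is expected to be small, a 1.6-fold higher number from compound 2 to compound 4 (0.20 log units; within the scatter), with no direction asserted beyond the scatter. Compound 4 is thus estimated at 25 nM, within 8 nM to 80 nM.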

Compound 4, half-maximal effective concentration: 295 nM
Beside the measured number, compound 4's estimate is 12-fold (1.07 log units) below it; the whole stated range lies below it.
By their numbers in this assay, from the lowest: compounds 2 and 1 (each within the scatter of the next); then compound 4; then compound 3.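

In this assay, the aromatic carbon bearing methoxy in compound 2 is not indifferent to what it carries: hydrogen in place of methoxy gives a 19-fold higher number from compound 2 to compound 4 (1.27 log units; beyond the scatter). Among these compounds, the earlier compounds showed this carbon only with oxygen-linked groups, methoxy in compound 2 and trifluoromethoxy in compound 1, so the step is the first view of it without a substituent. Nothing available explains the size of this step. Whether the oxygen itself matters stays open, since a methyl group or a chlorine atom on this carbon is not among the compounds shown.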